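Benzylsulfanyl variation on the nitroaryl enone acid series

A few compounds are considered here, and "the series" means these few. Any claim that something is new, unique, unknown or untested is made for them only; others in the source may bear on it.

Compound 1 `O=C(O)c1ccc(C(=O)/C(=C\c2ccc(F)c([N+](=O)[O-])c2)SCc2ccc(Cl)cc2)cc1` gives 50000 nM in a functional assay on DU-145 cells (Homo sapiens) for inhibition, read by trypan blue exclusion, with a stated time of 96 h (on this read-out lower numbers stand for stronger inhibition of growth and higher numbers for weaker inhibition of growth), the higher of the two numbers in hand; compound 2 `O=C(O)c1ccc(C(=O)/C(=C\c2ccc(Cl)c([N+](=O)[O-])c2)SCc2ccc(Cl)cc2)cc1` gives 1000 nM in this assay. Going by the values given here, the only measured step, a 50-fold lower number from compound 1 to compound 2 (1.70 log units; beyond the scatter), concerns chloro in place of fluoro on an aromatic carbon and leaves the (4-chlorobenzyl)sulfanyl group untouched. Compound 3 `Cc1ccc(CS/C(=C/c2ccc(F)c([N+](=O)[O-])c2)C(=O)c2ccc(C(=O)O)cc2)cc1` differs from compound 1 by methyl in place of chloro on an aromatic carbon. Among the compounds with values here, no measured step bears on this change, so no shift beyond the scatter is expected, and the step of no change at the digits printed from compound 1 to compound 3 (within the scatter) is taken as small. Compound 3 is therefore estimated at 50000 nM, with a range from 15000 nM to 150000 nM.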

Compound 3, concentration for 50% growth inhibition: 1000 nM
Compound 3: middle estimate off by 50-fold (1.70 log units), on the high side; measured number below the stated range.
By their numbers in this assay, from the lowest: compounds 2 and 3 (each within the scatter of the next); then compound 1.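

Swapping chloro for methyl on the benzyl ring, para to a large group, gives a 50-fold lower number from compound 1 to compound 3 (1.70 log units; beyond the scatter) in this assay. The (4-chlorobenzyl)sulfanyl group is therefore a second place where one change moves the number beyond the scatter, with the fluoro of compound 1 kept. No measurement in hand bears on the origin of this shift.

On these data alone, it remains open how an amine, a methoxy group or an unsubstituted benzyl would read at this position. As far as these compounds go, whether methyl in place of chloro gives a like step on the core of compound 2 is also open.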